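Removing the ethynyl group from compound 2

The source may report more compounds than this note shows. Statements on the series, on what has been measured and on what is new or still open speak of the compounds shown alone.

Measured compounds:
compound 1 `Cn1ncc2c(=O)n(-c3ccccc3)c(SCc3cccc(F)c3)cc21` — 240 nM
compound 2 `C#Cc1ccc(-n2c(SC(C)c3ccccc3)nc3c(cnn3C)c2=O)cc1` — 800 nM
compound 3 `O=c1c2cncn2nc(SCc2cccc(F)c2)n1-c1ccccc1` — 1600 nM

All three compounds were tested in an assay on isolated protein for inhibition of retinal dehydrogenase 2 (Homo sapiens); a lower number here means a stronger inhibitor, a higher number a weaker inhibitor. Among the three numbers, compound 2 stands second highest. Its nearest neighbour is compound 3, whose value lies within the usual scatter of repeated measurements, so the two cannot be told apart. The furthest is compound 1, whose lower value lies beyond the scatter.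

Compound 4 `CC(Sc1nc2c(cnn2C)c(=O)n1-c1ccccc1)c1ccccc1` has not been measured in this assay. It differs from compound 2 in one place: hydrogen in place of ethynyl on an aromatic carbon. The ethynyl group is small and carries no hydrogen-bond donor or acceptor. Among the compounds with values here, no measured pair shows this change on its own, so there is no step to lean on. A change of this size is expected to move the number little, most likely no further than the scatter, in either direction.

For compound 4 the estimated value in this assay is 1000 nM, within a range from 400 nM to 2500 nM. This estimate means a step of a 1.3-fold higher number from compound 2 to compound 4 (0.10 log units; within the scatter), expected to stay inside the scatter.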

Compound 4, half-maximal inhibitory concentration: 110 nM
Compound 4: middle estimate off by 9.1-fold (0.96 log units), on the high side; measured number outside the range, below it.
By their numbers in this assay, from the lowest: compound 4; then compound 1; then compounds 2 and 3 (each within the scatter of the next).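

Within the data shown here, measured in this assay and read as a single change, 4-ethynylphenyl to phenyl gives a 7.3-fold lower number from compound 2 to compound 4 (0.86 log units; beyond the scatter) and is the first step here between compounds that differ in one place. It shows that this position, on an aromatic carbon para to a large group, is sensitive: a group of only two carbons separates the two compounds by more than the scatter, and the plain phenyl of compound 4 is the stronger inhibitor of the pair. Nothing at hand says why the number moves.

Still open, as far as these compounds go, is how other groups at this carbon would compare with hydrogen and ethynyl, for example a fluorine, a methoxy or an amine. Also open, from the compounds shown here alone, is whether removing ethynyl would give a similar step on the cores of compound 1 and compound 3.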